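Shortening the Side Chain of Compound 1

The source may hold more compounds than are shown below. What is called first, only, known or untested is meant among the compounds shown, and "the series" means these compounds.

In a functional assay on the whole organism (stomach) with Rattus norvegicus as the target (a lower number here means that less compound is needed, a higher number that more compound is needed for the effect), compound 1 `N=C(S)CCCCCn1nc(-c2ccccc2)ccc1=O` gives 23.3 mg/kg, the lowest of the two numbers recorded; compound 3 `N=C(S)CCN1N=C(c2cccs2)CCC1=O` gives 77.3 mg/kg. Compound 2 `Cc1ccc(=O)n(CCCCCC(=N)S)n1` reaches only a limit of the assay, > 100 mg/kg. Within the data shown here, the one measured step, an at least 4.2-fold higher number from compound 1 to compound 2 (0.63 log units; beyond the scatter), concerns the phenyl and rests on that limit (the limit of > 100 mg/kg in this assay, at which 1 of the 3 values shown sits). Compound 4 `C/N=C(\S)CCn1nc(-c2ccccc2)ccc1=O` differs from compound 1 in another place: a group of 4 heavy atoms (2 carbon, 1 nitrogen, 1 sulfur; no ring) in place of a group of 6 heavy atoms (4 carbon, 1 nitrogen, 1 sulfur; no ring), on a saturated chain carbon, two bonds along the chain from an aromatic nitrogen. Among the measured compounds shown here, no measured step changes this chain, so the direction is open; compound 1 and compound 3, which differ in the chain and in the core, show only a higher number for the compound with the shorter chain. Compound 4 is therefore expected near 40 mg/kg, between 12 mg/kg and 130 mg/kg, an expected step of a 1.7-fold higher number from compound 1 to compound 4 (0.23 log units; within the scatter).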

Compound 4, dose for half-maximal effect: 58.5 mg/kg
For compound 4 the middle estimate is 1.5-fold (0.17 log units) below the measured one; low and high end bracket the measured number.
By their numbers in this assay, from the lowest: compound 1; then compounds 4 and 3 (each within the scatter of the next). At a limit, above all of these: compound 2.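

With the shared core held fixed, putting the group of 4 heavy atoms in place of the group of 6 heavy atoms gives a 2.5-fold higher number from compound 1 to compound 4 (0.40 log units; beyond the scatter) in this assay. Among these compounds, this is the first direct reading at this position: the smaller group, with 1 hydrogen-bond donor against 2, needs more compound. Nothing measured here explains the change.

Size and donor count change together, so the compounds shown cannot separate them. On these data alone, whether a longer chain or an amine in this place would lower the number remains open.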